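The compounds below may be only part of what the source reports. "The series", "measured", "known", "first", "only" and "open" are said of these compounds alone.

Measured so far:
Compound 1 `COc1ccc(S(=O)(=O)Nc2cc(Cl)cc(Cl)c2)cc1N1CCNCC1` gives 0.631 nM in an assay on isolated protein for binding affinity to 5-hydroxytryptamine receptor 6 (Homo sapiens); on this read-out lower numbers stand for stronger inhibition and higher numbers for weaker inhibition.
Compound 2 `COc1ccc(Cl)cc1NS(=O)(=O)c1ccc(OC)c(N2CCNCC2)c1` gives 1.26 nM.
Compound 3 `COc1ccc(S(=O)(=O)Nc2cc(Cl)c(Cl)cc2Cl)cc1N1CCNCC1` gives 5.01 nM.

Compound 3 gives the highest of the three numbers in this assay; the nearest is compound 2, with a 4.0-fold higher number from compound 2 to compound 3 (0.60 log units; beyond the scatter), and the furthest is compound 1, with a 7.9-fold higher number from compound 1 to compound 3 (0.90 log units; beyond the scatter). Compound 4 `COc1ccc(S(=O)(=O)Nc2cc(Cl)cc(Cl)c2Br)cc1N1CCNCC1` differs from compound 3 in one place: 2-bromo-3,5-dichlorophenyl in place of 2,4,5-trichlorophenyl on a sulfonamide nitrogen. The step of a 7.9-fold higher number from compound 1 to compound 3 (0.90 log units; beyond the scatter) bears most on this. Compound 4 keeps the 3,5-dichlorophenyl of compound 1 and adds only a bromine. Part of that modest loss is expected to be recovered, so compound 4 is estimated at 2 nM, between 0.5 nM and 8 nM. The expected step, a 2.5-fold lower number from compound 3 to compound 4 (0.40 log units; beyond the scatter), is of modest size.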

Compound 4, inhibition constant: 3.16 nM
Compound 4: the middle estimate sits 1.6-fold (0.20 log units) below what was measured, and the stated range covers the measured number.
By their numbers in this assay, from the lowest: compounds 1 and 2 (each within the scatter of the next); then compounds 4 and 3 (each within the scatter of the next).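

In this assay, bromo in place of hydrogen on an aromatic carbon of the 3,5-dichlorophenyl group weakens binding (a 5.0-fold higher number from compound 1 to compound 4 (0.70 log units; beyond the scatter)). For the compounds shown here, this single added atom therefore matters, and it gives the first direct reading of a change made to that ring alone. The 2-bromo-3,5-dichlorophenyl group and the 2,4,5-trichlorophenyl group cannot be told apart (a 1.6-fold lower number from compound 3 to compound 4 (0.20 log units; within the scatter)), whereas the gap from the 5-chloro-2-methoxyphenyl group is real though modest (a 2.5-fold higher number from compound 2 to compound 4 (0.40 log units; beyond the scatter)).

From the compounds shown here alone, how an amine or a carboxylic acid in place of the bromo would read remains open. Nothing shown gives a reason for these steps.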